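Pyrazole amide series: reversed amide with cyclopentyl in place of arylamide

A few compounds are considered here, and "the series" means these few. Any claim that something is new, unique, unknown or untested is made for them only; others in the source may bear on it.

Of the compounds shown here, two carry values so far. Compound 1 `Cc1cc(C(=O)Nc2ccc(F)cc2)nn1Cc1cc(Cl)ccc1OCc1ccccc1` gives 79.4 nM in an assay on CHO-K1 cells for displacement of a labelled ligand from prostaglandin E2 receptor EP1 subtype (Homo sapiens) (a higher number here means a weaker inhibitor, a lower number a stronger inhibitor), the lowest of the two numbers; compound 2 `Cc1cc(C(=O)NN2CCCCC2)nn1Cc1cc(Cl)ccc1OCC(C)C` gives 200 nM in this assay, and the gap between these two lies beyond the scatter. Compound 3 `Cc1cc(NC(=O)C2CCCC2)nn1Cc1cc(Cl)ccc1OCc1ccccc1` keeps the core of compound 1 and differs in one place: (cyclopentylcarbonyl)amino in place of (4-fluorophenyl)carbamoyl on an aromatic carbon. Within the data shown here, no step between measured compounds is known for this change, so the estimate rests on compound 1 at 79.4 nM alone. A modest weakening beyond the scatter is expected, with a 2.0-fold higher number from compound 1 to compound 3 (0.30 log units; within the scatter). Compound 3 is estimated at 160 nM, within 50 nM to 500 nM.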

Compound 3, half-maximal inhibitory concentration: 15.9 nM
Compound 3: the middle estimate sits 10-fold (1.00 log units) above what was measured; the whole stated range lies above it.
By their numbers in this assay, from the lowest: compound 3; then compound 1; then compound 2.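

In this assay, the (4-fluorophenyl)carbamoyl group is not needed for binding at this position: (cyclopentylcarbonyl)amino gives a 5.0-fold lower number from compound 1 to compound 3 (0.70 log units; beyond the scatter). This single step changes both the direction of the amide and the ring, from six-membered aromatic to five-membered non-aromatic, so the two changes cannot be separated. No data at hand bear on the reason for this step. Still open, as far as these compounds go, is whether the amide direction or the ring accounts for the step, and a 4-fluorobenzoylamino group would help to separate them. Also open, from the compounds shown here alone, is how a cyclohexyl ring or a butyl chain would compare with cyclopentyl.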